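Cyclohexyl for trifluoromethyl on the shared core

The source may hold more compounds than are shown below. What is called first, only, known or untested is meant among the compounds shown, and "the series" means these compounds.

The series shares the core of compound 2 `C[C@H](NC(=O)c1c(C(F)(F)F)nnn1Cc1ccc(C(F)(F)F)cc1)c1ccc(C(=O)O)cc1`, an amide joining the acid-bearing side chain to a five-membered aromatic ring with 3 nitrogen. In a functional assay on CHO cells for antagonist activity at prostaglandin E2 receptor EP4 subtype (Homo sapiens), read by calcium flux, with a stated time of 15 min (a higher number here means a weaker inhibitor, a lower number a stronger inhibitor), compound 2 gives 225 nM. Going by the values given here, compound 3 `C[C@H](NC(=O)c1c(C(F)(F)F)nnn1Cc1cccc(C(F)(F)F)c1)c1ccc(C(=O)O)cc1` carries the 3-(trifluoromethyl)phenyl instead and in this assay gives 1970 nM; the step of an 8.8-fold higher number from compound 2 to compound 3 (0.94 log units; beyond the scatter) is the only single-point change measured so far. Compound 1 `C[C@H](NC(=O)c1nnn(Cc2cccc(C(F)(F)F)c2)c1C(F)(F)F)c1ccc(C(=O)O)cc1` differs from compound 2 in two places at once. In this assay compound 1 reaches only a limit, > 10000 nM, and that is a limit rather than a number (the limit of > 10000 nM in this assay, at which 1 of the 3 values shown sits). Compound 2 therefore stands lowest of the two numbers in hand.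

Compound 4 `C[C@H](NC(=O)c1c(C2CCCCC2)nnn1Cc1ccc(C(F)(F)F)cc1)c1ccc(C(=O)O)cc1` is the next entry; against compound 2, (cyclohexyl in place of trifluoromethyl on an aromatic carbon). Among the compounds with values here, no measured step touches this ring carbon: the one step in hand concerns the benzyl group alone, so nothing in the data fixes the size or direction of the change in this assay. Compound 4 is estimated at 400 nM, with a range of 100 nM to 2000 nM. That estimate corresponds to an expected step of a 1.8-fold higher number from compound 2 to compound 4 (0.25 log units; within the scatter).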

Compound 4, half-maximal inhibitory concentration: 161 nM
Estimate against measurement, compound 4: 2.5-fold (0.40 log units) above; the measured number falls inside the stated range.
By their numbers in this assay, from the lowest: compounds 4 and 2 (each within the scatter of the next); then compound 3. At a limit, above all of these: compound 1.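

In this assay, going by these compounds alone, the first measured change at this ring carbon gives a 1.4-fold lower number from compound 2 to compound 4 (0.15 log units; within the scatter), so trifluoromethyl and cyclohexyl cannot be told apart at this position. For these two compounds, the ring carbon carries either 4 heavy atoms with no ring or 6 heavy atoms in a six-membered non-aromatic ring of carbon only, and the two values stay within the scatter. Nothing in the data in hand accounts for this result.

Still open, as far as these compounds go, is how an amine, a carboxylic acid, a phenyl ring or a longer chain would read at this ring carbon, since two groups alone define no trend. Also open, from the compounds shown here alone, is whether cyclohexyl would read the same alongside the 3-(trifluoromethyl)phenyl of compound 3.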